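A dimethylamino swap on compound 2

The compounds below may be only part of what the source reports. "The series", "measured", "known", "first", "only" and "open" are said of these compounds alone.

- compound 1 `Cc1ccc2[nH]c(-c3ccc(-c4ccc(-c5ccc(N(C)C)cc5)cc4)cc3)nc2c1`: 6240 nM
- compound 2 `Oc1ccc(-c2ccc(-c3ccc(-c4nc5c(O)cccc5[nH]4)cc3)cc2)cc1`: 3190 nM

In a functional assay on KB cells (Homo sapiens) for inhibition, read by sulforhodamine B assay (a lower number here means a stronger inhibitor of growth, a higher number a weaker inhibitor of growth), compound 2 gives 3190 nM and compound 1 gives 6240 nM within the usual scatter of each other. Next stands compound 3 `CN(C)c1ccc(-c2ccc(-c3ccc(-c4nc5c(O)cccc5[nH]4)cc3)cc2)cc1` with dimethylamino in place of hydroxy on an aromatic carbon, para to a large group dimethylamino in place of hydroxy on an aromatic carbon on the core of compound 2. Like compound 3, compound 1 carries dimethylamino and gives 6240 nM on a different core. In this assay the expectation is a small move toward a higher number, none beyond the scatter. The estimated size is a 1.3-fold higher number from compound 2 to compound 3 (0.12 log units; within the scatter) for this change. For compound 3 the estimated value is 4200 nM within a range from 1600 nM to 11000 nM in this estimate.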

Compound 3, concentration for 50% growth inhibition: 4200 nM
Beside the measured number, compound 3's estimate shows no gap at the digits printed, and the stated range covers the measured number.
By their numbers in this assay, from the lowest: compounds 2, 3 and 1 (each within the scatter of the next).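

Exchanging hydroxy for dimethylamino on an aromatic carbon, para to a large group, gives a 1.3-fold higher number from compound 2 to compound 3 (0.12 log units; within the scatter) in this assay and so leaves the growth inhibition of this series within the scatter. With dimethylamino held in place, 4-hydroxy-1H-benzimidazol-2-yl in place of 5-methyl-1H-benzimidazol-2-yl gives a 1.5-fold lower number from compound 1 to compound 3 (0.17 log units; within the scatter) and so also stays within the scatter. Nothing measured here speaks to what lies behind these two steps. Open, going by these compounds, is whether a primary amine or a carboxylic acid at this position would stay within the same scatter.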